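Phenyl to hydroxy-phenoxy chain on the amine arm

The compounds below may be only part of what the source reports. "The series", "measured", "known", "first", "only" and "open" are said of these compounds alone.

Measured compounds:
compound 1 `CN(CCCN1C(=O)CSC1c1cc(C(C)(C)C)c(O)c(C(C)(C)C)c1)CC1CC1`: 1200 nM
compound 2 `CN(CCCN1C(=O)CSC1c1cc(C(C)(C)C)c(O)c(C(C)(C)C)c1)Cc1ccccc1`: 600 nM

In a functional assay on aorta for inhibition of Voltage-dependent L-type calcium channel subunit alpha-1C (Rattus norvegicus) (on this read-out higher numbers stand for weaker inhibition and lower numbers for stronger inhibition), compound 2 gives 600 nM, and compound 1 gives 1200 nM. Among the compounds with values here, the only known step is a 2.0-fold lower number from compound 1 to compound 2 (0.30 log units; within the scatter), so the two numbers sit within the scatter of each other. Compound 3 `CN(CCCN1C(=O)CSC1c1cc(C(C)(C)C)c(O)c(C(C)(C)C)c1)CC(O)COc1ccccc1` differs from compound 2 by 1-hydroxy-2-phenoxyethyl in place of phenyl on a saturated chain carbon bound to an amine nitrogen. Within the data shown here, no measured step covers an added hydroxy or phenoxy group, and the one step known was small, so for compound 3 the expected change is no change at the digits printed from compound 2 to compound 3 (within the scatter), not beyond the scatter. Compound 3 is therefore estimated at 600 nM, within 200 nM to 2000 nM.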

Compound 3, half-maximal inhibitory concentration: 420 nM
Compound 3: middle estimate off by 1.4-fold (0.15 log units), on the high side, and the stated range covers the measured number.
By their numbers in this assay, from the lowest: compounds 3, 2 and 1 (each within the scatter of the next, the first and the last beyond it).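

The amine arm takes the larger 1-hydroxy-2-phenoxyethyl group in place of phenyl with no step beyond the scatter in this assay, only a 1.4-fold lower number from compound 2 to compound 3 (0.15 log units; within the scatter). Set against cyclopropyl, the same group gives a modest step, a 2.9-fold lower number from compound 1 to compound 3 (0.46 log units; beyond the scatter), the only one here beyond the scatter. Nothing measured bears on why these numbers fall as they do.

From the compounds shown here alone, how an arm carrying 3-phenoxypropyl without the hydroxy group would read remains open, so the hydroxy and phenoxy parts cannot be told apart. Also open, going by these compounds, is how a carboxylic acid or a second amine on this arm would read.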